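This account rests on a few compounds, and the source may have more. Where it says the series, first, only, none or still open, it means among the compounds named here.

Compounds measured so far:
- compound 1 `CO/N=C/C=C/c1ccccc1OC(=O)c1ccccc1`
- compound 2 `CC(=O)ONC(=O)/C=C/c1ccccc1OC(=O)c1ccccc1`
- compound 3 `O=C(/C=C/c1ccccc1O)NO`

In a functional assay on SK-OV-3 cells (Homo sapiens) for inhibition, read by ELISA, with a stated time of 24 h (on this read-out lower numbers stand for stronger inhibition of growth and higher numbers for weaker inhibition of growth), compound 1 gives only a limit, > 100000 nM. Compound 2 gives 16800 nM and compound 3 gives 50400 nM. On the numbers shown, compound 2 stands lowest of the two numbered values, with compound 3 the nearest at a higher number; the value for compound 1 is a limit, as noted in the limit of > 100000 nM in this assay, at which 1 of the 3 values shown sits. Going by the values given here, the one measured step is an at least 5.9-fold lower number from compound 1 to compound 2 (0.77 log units; beyond the scatter), which exchanged the group on the double-bonded chain carbon. Compound 3, which differs from compound 2 in two places, cannot be read as a single step.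

Compound 4 `CN1CCN(C(=O)ONC(=O)/C=C/c2ccccc2OC(=O)c2ccccc2)CC1` is not yet measured. It differs from compound 2 by 4-methylpiperazin-1-yl in place of methyl on a carbonyl carbon, that is acetoxy becomes ((4-methylpiperazin-1-yl)carbonyl)oxy. Among the compounds with values here, no measured step touches this carbonyl carbon, so the step from compound 1 to compound 2 gives no direct guide, and no change beyond the scatter is expected in this assay. Compound 4 is therefore expected to give about 15000 nM, within 5000 nM to 50000 nM, a step of a 1.1-fold lower number from compound 2 to compound 4 (0.05 log units; within the scatter) that is estimated to stay within the scatter.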

Compound 4, concentration for 50% growth inhibition: > 100000 nM
Compound 4 was reported as a limit; the forecaster's own chance of this, stated with the estimate: 5%; at least 6.6-fold (0.82 log units) between middle value and limit.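

In this assay, going by these compounds alone, the carbonyl carbon that carries the methyl of the acetoxy group turns out to be a sensitive place, which the earlier compounds could not show, as none of their steps touched it: 4-methylpiperazin-1-yl in place of methyl gives an at least 5.9-fold higher number from compound 2 to compound 4 (0.77 log units; beyond the scatter). Growth inhibition at the level of compound 2 therefore does not survive the change from acetoxy to ((4-methylpiperazin-1-yl)carbonyl)oxy on the shared core, so this position does not accept every replacement. The reading for compound 4 is a limit and not a number, and it is the same limit as that of compound 1: the limit of > 100000 nM in this assay, at which 2 of the 4 values shown sit.

With a single replacement on this carbonyl carbon, the compounds shown cannot separate the contribution of the ring from that of its nitrogen atoms, or from that of the terminal methyl on the ring. On these data alone, whether a small open amine such as dimethylamino, a morpholin-4-yl ring or a longer alkyl chain such as propyl on the same carbonyl carbon would stay close to compound 2 remains open.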